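The source may report more compounds than this note shows. Statements on the series, on what has been measured and on what is new or still open speak of the compounds shown alone.

Two compounds have been measured in an ADME assay on MT4 cells (Homo sapiens) for cytotoxicity, read by MTT assay; on this read-out higher numbers stand for lower toxicity in this test and lower numbers for higher toxicity in this test:

Compound 1 `O=c1cc(Cc2c(F)cccc2F)nc(Sc2ccccc2)[nH]1`: > 76000 nM, a limit of the assay.
Compound 2 `Cc1c(Cc2c(F)cccc2F)nc(SCc2ccc([N+](=O)[O-])cc2)[nH]c1=O`: > 37000 nM, a limit of the assay.

Neither compound has given an actual number in this assay. Compound 2 therefore has no exact place on the scale: its entry of > 37000 nM is only a limit. The one other entry, for compound 1, is also only a limit, so the two compounds cannot be ranked against each other.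

The next compound to be tested is compound 3 `Cc1c(Cc2c(F)cccc2F)nc(SCc2ccncc2)[nH]c1=O`. It differs from compound 2 in one place, with pyridin-4-yl in place of 4-nitrophenyl on a saturated chain carbon bound to a sulfur.

Going by the values given here, no measured step between two compounds is available as a guide. The expectation rests instead on compound 2, whose > 37000 nM is a limit. No change beyond the usual scatter is expected in this assay, and no direction is favoured with any confidence. The expected step, a step that the limit leaves unreadable from compound 2 to compound 3, is an estimate and could not be told apart from that scatter. The value for compound 3 is estimated at 50000 nM, with an expected range of 12000 nM to 200000 nM.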

Compound 3, half-maximal cytotoxic concentration: > 70000 nM
Compound 3: only a limit was reported; the forecaster's own chance of this, stated with the estimate: 55%; middle value at least 1.4-fold (0.14 log units) from the limit.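

Compound 3 gives > 70000 nM in this assay, which is a limit of the assay. Compound 2 also stands only at a limit, so no step can be read from compound 2 to compound 3. The compounds shown leave open where any of the three would give an actual number in this assay, and how they would rank.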